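A 4-methoxyphenyl group on the ring amide nitrogen

The compounds below may be only part of what the source reports. "The series", "measured", "known", "first", "only" and "open" are said of these compounds alone.

Compound 1 (`O=C1COc2ccc(-c3cccc(NS(=O)(=O)c4ccc(F)cc4)c3)cc2N1`) was tested in a functional assay on HepG2 cells (Homo sapiens) for antiproliferative activity, read by MTT assay, with a stated time of 72 h (a lower number here means a stronger inhibitor, a higher number a weaker inhibitor), and gives > 40000 nM, which is a limit of the assay and not a number. Compound 4 (`COc1ccc(N2C(=O)COc3ccc(-c4cccc(NS(=O)(=O)c5ccc(F)cc5)c4)cc32)cc1`) has not yet been measured and departs from compound 1 by a single change: 4-methoxyphenyl in place of hydrogen on an amide-type nitrogen in a ring. In words, 4-methoxyphenyl takes the place of hydrogen on an amide-type nitrogen in a ring.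

The nearest evidence concerns the group on that same kind of nitrogen. Compound 2 (`COc1ccc(N2C(=O)COc3ccc(-c4cnc(Cl)c(NS(=O)(=O)c5ccc(F)cc5)c4)cc32)cc1`) carries 4-methoxyphenyl there and gives > 40000 nM, which is also a limit. Compound 3 (`CC(C)N1C(=O)COc2ccc(-c3cnc(Cl)c(NS(=O)(=O)c4ccc(F)cc4)c3)cc21`) carries isopropyl there and gives 21500 nM. Going by the values given here, the one measured step is an at least 1.8-fold lower number from compound 2 to compound 3 (0.26 log units; that floor lies within the scatter). Among the compounds with values here, it exchanges one group for another, and no measured step replaces hydrogen on this nitrogen. Any step starting from compound 1 can only be read against (the limit of > 40000 nM in this assay, at which 2 of the 3 values shown sit).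

In this assay, therefore, no step beyond the scatter is expected in either direction, and a further limit is the likeliest report. The estimated step is a step that the limit leaves unreadable from compound 1 to compound 4. For compound 4 the estimated value is 45000 nM, with an expected range from 20000 nM to 90000 nM.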

Compound 4, half-maximal inhibitory concentration: 29800 nM
Compound 4: the middle estimate sits 1.5-fold (0.18 log units) above what was measured; measured number inside the range.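

In this assay compound 1 gives > 40000 nM, which is a limit of the assay and not a number. Putting 4-methoxyphenyl in place of hydrogen on the amide-type nitrogen gives an at least 1.3-fold lower number from compound 1 to compound 4 (0.12 log units; that floor lies within the scatter), the only step shown that starts from hydrogen at this position, and it shows that a group with an aromatic ring can stand there while the compound still returns a number in this assay. That step cannot be called a real gain, and its true size stays unknown, because its starting point is a limit and its floor lies within the usual scatter: the limit of > 40000 nM in this assay, at which 2 of the 4 values shown sit.

The compounds shown leave open how a simple methyl, a longer chain or a chain ending in an amine would read on this nitrogen with the core of compound 1. They also leave open whether isopropyl, shown here only with the core of compound 3, would give a value on the core of compound 1 that differs from that of compound 4 by more than the scatter.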